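Two esters at the assay limit and a hybrid third

The compounds below may be only part of what the source reports. "The series", "measured", "known", "first", "only" and "open" are said of these compounds alone.

Compound 1 `CC(C)c1cccc(OC(=O)c2cn(-c3ccccc3)nc2-c2cccnc2)c1`: > 100000 nM
Compound 2 `CCc1ccc(OC(=O)c2cn(-c3ccccc3)nc2-c2ccncc2)cc1`: > 100000 nM

In a functional assay on HeLa cells (Homo sapiens) for cytotoxicity, read by MTT assay, with a stated time of 48 h (on this read-out higher numbers stand for weaker inhibition and lower numbers for stronger inhibition), compound 1 gives > 100000 nM, which is a limit of the assay rather than a number. Compound 2 likewise gives > 100000 nM in this assay, again a limit and not a measured value. Compound 2 therefore stands exactly where every value shown stands, namely at the limit of > 100000 nM in this assay, at which 2 of the 2 values shown sit, and no difference between the two measured compounds can be sized.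

Compound 3 `CC(C)c1cccc(OC(=O)c2cn(-c3ccccc3)nc2-c2ccncc2)c1` differs from compound 2 by 3-isopropylphenyl in place of 4-ethylphenyl on an oxygen next to a carbonyl group. Both measured compounds share the ester linkage and the phenyl group on the core, and the 3-isopropylphenyl group that enters in compound 3 is already present in compound 1, which also sits at the limit. With both neighbours of the hybrid at the limit, the step from compound 2 to compound 3 is expected to be none beyond the scatter, with compound 3 expected to remain at the limit as well; the expected step is a number no higher from compound 2 to compound 3 (the limit leaves the size open). Compound 3 is accordingly estimated at 100000 nM in this assay, within a range from 50000 nM to 300000 nM.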

Compound 3, half-maximal inhibitory concentration: > 100000 nM
Compound 3 was reported as a limit; the forecaster's own chance of this, stated with the estimate: 85%; the middle value lies on the limit itself.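

In this assay, going by these compounds alone, compound 3 gives > 100000 nM, which is a limit of the assay and not a number, so no step from compound 1 or compound 2 to compound 3 can be read. The compounds shown leave open how far each lies from that shared limit, and whether either exchange alters the read-out at all.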